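Cytotoxicity notes: from compound 2 to compound 4

This account rests on a few compounds, and the source may have more. Where it says the series, first, only, none or still open, it means among the compounds named here.

The series shares the core of compound 1 `COc1ccc([C@H]2CC(=O)N(c3ccc(N)cc3)C2)cc1OC1CCCC1` and varies the aryl group on an amide-type nitrogen in a ring. In a functional assay on HEK293 cells (Homo sapiens) for cytotoxicity (a lower number here means that less compound is tolerated, a higher number that more compound is tolerated), compound 1 reaches only the limit > 10000 nM. Compound 2 `COc1ccc([C@H]2CC(=O)N(c3cccc(C(F)(F)F)c3)C2)cc1OC1CCCC1` carries 3-(trifluoromethyl)phenyl in place of 4-aminophenyl; in this assay compound 2 likewise sits at the limit > 10000 nM, so no number is known for it. Compound 3 `COc1ccc([C@H]2CC(=O)N(c3cccnc3)C2)cc1OC1CCCC1` bears pyridin-3-yl; in this assay compound 3 stops at the limit > 10000 nM. Hence a step that the two limits leave unreadable from compound 1 to compound 2, a step that the two limits leave unreadable from compound 1 to compound 3 and a step that the two limits leave unreadable from compound 2 to compound 3 cannot be read, since (the limit of > 10000 nM in this assay, at which 3 of the 3 values shown sit).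

Compound 4 `COc1ccc([C@H]2CC(=O)N(c3cccc(NS(=O)(=O)c4c(F)cccc4F)c3)C2)cc1OC1CCCC1` differs from compound 2 by ((2,6-difluorophenyl)sulfonyl)amino in place of trifluoromethyl on an aromatic carbon. For the measured compounds named here, no measured step bears directly on this change: the exchanges of the aryl group on the amide-type nitrogen were all unreadable, and none of them altered a substituent on that aryl ring. Going by the values given here, every compound measured so far has been tolerated up to the limit, and compound 4 is expected to behave alike, with a step that the limit leaves unreadable from compound 2 to compound 4 not beyond the scatter. Compound 4 is therefore estimated at 20000 nM, range 8000 nM to 60000 nM, most likely reported as a limit once more.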

Compound 4, half-maximal cytotoxic concentration: > 10000 nM
Compound 4 was reported as a limit; the forecaster's own chance of this, stated with the estimate: 85%; the middle value does not contradict the limit.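

In this assay compound 4 gives > 10000 nM, which is a limit and not a number. The change from compound 2 to compound 4 therefore yields no readable step, since both compounds stop at a limit: the limit of > 10000 nM in this assay, at which 4 of the 4 values shown sit.

The compounds shown leave open whether any of them has a true number in this assay, and whether the aryl group or its substituents shift that number at all.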